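This account rests on a few compounds, and the source may have more. Where it says the series, first, only, none or still open, it means among the compounds named here.

The three measured compounds in an ADME assay on microsomes from liver (Homo sapiens) for metabolic stability (a lower number here means that the compound disappears faster, a higher number that the compound lasts longer), are:
compound 1, `Cn1cc(-c2ccc(F)cc2)c(=O)c2c(Nc3ccc(Oc4ccnc(NC(=O)C5CC5)c4)c(F)c3)nccc21`, with 14.7 h;
compound 2, `CC(O)C(=O)Nc1cc(Oc2ccc(Nc3nccc4[nH]cc(-c5ccc(F)cc5)c(=O)c34)cc2F)ccn1`, with 4.15 h;
compound 3, `Nc1nccc(Oc2ccc(Nc3nccc4[nH]cc(-c5ccc(F)cc5)c(=O)c34)cc2F)c1Cl`, with 3.16 h.

Compound 2 stands second highest of these three numbers. Its nearest neighbour is compound 3, and the step of a 1.3-fold lower number from compound 2 to compound 3 (0.12 log units; within the scatter) lies within the scatter, so the two are not told apart. Among the measured compounds shown here, compound 1 is the furthest from compound 2; no single-place step connects them, so only the two values can be set side by side, and they show compound 1 lasting longer in this assay than compound 2.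

Compound 4, `O=C(CO)Nc1cc(Oc2ccc(Nc3nccc4[nH]cc(-c5ccc(F)cc5)c(=O)c34)cc2F)ccn1`, differs from compound 2 in one place: hydrogen in place of methyl on a saturated chain carbon bound to a carbonyl carbon and an oxygen on a saturated carbon. For the measured compounds named here, the only measured single-place step, a 1.3-fold lower number from compound 2 to compound 3 (0.12 log units; within the scatter), concerns a different change, 2-amino-3-chloropyridin-4-yl in place of 2-(((1-hydroxyethyl)carbonyl)amino)pyridin-4-yl, and was itself within the scatter. Going by the values given here, no measured step bears directly on the loss of the methyl from the 1-hydroxyethyl group. Among the compounds with values here, with one carbon leaving and the counts of hydrogen-bond donors and acceptors unchanged, the account expects no step in this assay beyond the scatter, in either direction.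

Compound 4 is therefore expected to give about 4 h in this assay, within a range from 2 h to 8 h. The step of a 1.0-fold lower number from compound 2 to compound 4 (0.02 log units; within the scatter) is expected to stay within the scatter.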

Compound 4, half-life: 7.23 h
For compound 4 the middle estimate is 1.8-fold (0.26 log units) below the measured one; the range from low to high includes it.
By their numbers in this assay, from the lowest: compounds 3, 2 and 4 (each within the scatter of the next, the first and the last beyond it); then compound 1.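

Hydrogen in place of methyl on a saturated chain carbon bound to a carbonyl carbon and an oxygen on a saturated carbon gives a 1.7-fold higher number from compound 2 to compound 4 (0.24 log units; within the scatter), so 1-hydroxyethyl and hydroxymethyl are not told apart in this assay. At the group on an oxygen on an aromatic ring, however, the compounds now show a step that can be told apart: a 2.3-fold higher number from compound 3 to compound 4 (0.36 log units; beyond the scatter), with 2-(((hydroxymethyl)carbonyl)amino)pyridin-4-yl in place of 2-amino-3-chloropyridin-4-yl. The corresponding earlier comparison with the 1-hydroxyethyl amide, a 1.3-fold lower number from compound 2 to compound 3 (0.12 log units; within the scatter), did not separate the two groups, and because compound 2 lies within the scatter of both compound 3 and compound 4, this modest difference rests on a single pair.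

No evidence is available to account for either step. As far as these compounds go, whether a longer chain, an amine or a carboxylic acid in place of the hydroxymethyl would stay level with compound 4 in this assay remains open, as does the source of the separate standing of compound 1 at 14.7 h, which differs from the others in more than one place.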